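The source may report more compounds than this note shows. Statements on the series, on what has been measured and on what is new or still open speak of the compounds shown alone.

Measured in an assay on cells for inhibition of sodium- and chloride-dependent glycine transporter 1 (Homo sapiens); a higher number here means that more compound is needed for the effect, a lower number that less compound is needed:

Compound 1, `COc1cc(C(F)(F)F)cc(SC)c1C(=O)NC1(c2cccc(Cl)c2)CCCN(C)C1` — 25 nM
Compound 2, `COc1cccc(C2(NC(=O)c3c(OC)cc(C(F)(F)F)cc3SC)CCCN(C)C2)c1` — 110 nM
Compound 3, `COc1cc(C(F)(F)F)cc(SC)c1C(=O)NC1(c2cccnc2)CCCN(C)C1` — 54 nM

Compound 3 stands second highest of the three numbers in this assay: compound 2 sits at a 2.0-fold lower number from compound 2 to compound 3 (0.31 log units; beyond the scatter) from it, and compound 1 at a 2.2-fold higher number from compound 1 to compound 3 (0.33 log units; beyond the scatter), both steps beyond the scatter but modest.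

Compound 4 is `COc1cc(C(F)(F)F)cc(SC)c1C(=O)NC1(c2ccncc2)CCCN(C)C1`. It differs from compound 3 only at the saturated ring carbon of the shared core: pyridin-4-yl in place of pyridin-3-yl on a saturated ring carbon.

Going by the values given here, no measured step exchanges one pyridinyl isomer for another, so nothing bears directly on this change. The steps that do touch the same position are all modest: a 4.4-fold higher number from compound 1 to compound 2 (0.64 log units; beyond the scatter), a 2.2-fold higher number from compound 1 to compound 3 (0.33 log units; beyond the scatter) and a 2.0-fold lower number from compound 2 to compound 3 (0.31 log units; beyond the scatter). Three different aromatic groups at this carbon span only a narrow band, so a move within that band is expected for compound 4, with no firm direction; a small shift toward a higher number is taken as the centre, since compound 3 already lies toward the upper part of the set.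

Compound 4 is therefore estimated at 80 nM in this assay, with a range of 30 nM to 250 nM, meaning an expected step of a 1.5-fold higher number from compound 3 to compound 4 (0.17 log units; within the scatter).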

Compound 4, half-maximal effective concentration: 60 nM
Compound 4: middle estimate off by 1.3-fold (0.12 log units), on the high side; measured number inside the range.
By their numbers in this assay, from the lowest: compound 1; then compounds 3, 4 and 2 (each within the scatter of the next, the first and the last beyond it).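

In this assay, pyridin-4-yl in place of pyridin-3-yl on the saturated ring carbon gives a 1.1-fold higher number from compound 3 to compound 4 (0.05 log units; within the scatter), so this first exchange of one pyridinyl isomer for the other separates compound 3 and compound 4 by no more than the scatter. The comparisons with the substituted phenyl compounds differ: pyridin-4-yl in place of 3-methoxyphenyl gives a 1.8-fold lower number from compound 2 to compound 4 (0.26 log units; within the scatter), while pyridin-4-yl in place of 3-chlorophenyl gives a 2.4-fold higher number from compound 1 to compound 4 (0.38 log units; beyond the scatter), leaving compound 1 clear of both pyridinyl compounds, whereas compound 2 stands clear of compound 3 but not of compound 4. Nothing available explains these numbers or the absence of a separation between the two pyridinyl isomers.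

As far as these compounds go, it remains open whether the same narrow band would hold for pyridin-2-yl, for unsubstituted phenyl or for a saturated group such as cyclohexyl at this carbon. From the compounds shown here alone, it is also open whether a chloro group on a pyridin-3-yl or pyridin-4-yl ring would bring the number toward that of compound 1.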